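This account rests on a few compounds, and the source may have more. Where it says the series, first, only, none or still open, it means among the compounds named here.

Three compounds share one core: compound 1 `O=C(Nc1cccc(S(=O)(=O)Nc2ccccc2)c1)c1ccc(Cl)cc1Cl`, compound 2 `O=C(Nc1ccc(S(=O)(=O)NCc2ccccc2)cc1)c1ccc(Cl)cc1Cl` and compound 3 `O=C(Nc1ccc(S(=O)(=O)Nc2ccccc2)cc1)c1ccc(Cl)cc1Br`. In a functional assay on HEK293 cells for agonist activity at probable G-protein coupled receptor 27 (Homo sapiens), read by a luciferase reporter and beta-arrestin recruitment, with a stated time of 10 min (a lower number here means a smaller maximal response, a higher number a larger maximal response), compound 1 gives "not determined" (no result reported) and compound 2 gives "not determined" (no result reported), so neither offers a number to work with. Going by the values given here, compound 3 stands alone with a value: in this assay compound 3 gives 123%, a full response, and with no second number no step between measured compounds can be drawn. Compound 4 `O=C(Nc1ccc(S(=O)(=O)Nc2ccccc2)cc1)c1ccc(Cl)cc1F` differs from compound 3 in one place: fluoro in place of bromo on an aromatic carbon. Resting on that single point, the expected step in this assay is a number 13 percentage points lower from compound 3 to compound 4 (beyond the scatter), a modest drop that may well stay inside the usual scatter. Compound 4 is therefore estimated to give 110%, within 80% to 140%.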

Compound 4, largest response reached (Emax), in percent of the reference or control that the assay uses: 57%
Estimate against measurement, compound 4: 53 percentage points above; the whole stated range lies above it.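

In this assay, exchanging bromo for fluoro at this aromatic carbon gives a number 66 percentage points lower from compound 3 to compound 4 (beyond the scatter), so replacing one heavy atom with another here can substantially change the maximal response. The counted hydrogen-bond donors, acceptors and net charge of the two groups are the same, and nothing available explains the difference. The compounds shown leave open how a hydrogen, a methoxy group or an amine at this carbon would compare with bromo and fluoro. The results for compound 1 and compound 2 offer no number, so they add nothing to this comparison.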